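The source may hold more compounds than are shown below. What is called first, only, known or untested is meant among the compounds shown, and "the series" means these compounds.

The series shares one core, seen in compound 1 `O=c1nc(NC2CC2)sc2c([N+](=O)[O-])cc(C(F)(F)F)cc12` and compound 2 `O=c1nc(NC2CCCC2)sc2c([N+](=O)[O-])cc(C(F)(F)F)cc12`. In an ADME assay on Vero cells (Chlorocebus sabaeus) for cytotoxicity, read by MTT assay, with a stated time of 72 h (a higher number here means a weaker inhibitor, a lower number a stronger inhibitor), compound 1 reaches only the limit of the measurement, > 100000 nM. In this assay compound 2 likewise gives only a limit, > 100000 nM. Going by the values given here, the single measured step, a step that the two limits leave unreadable from compound 1 to compound 2, therefore cannot be read, and compound 2 stands, like every value shown, at the limit of > 100000 nM in this assay, at which 2 of the 2 values shown sit. Compound 3 `O=c1nc(N2CCCC2)sc2c([N+](=O)[O-])cc(C(F)(F)F)cc12` differs from compound 2 by pyrrolidin-1-yl in place of cyclopentylamino on an aromatic carbon. No readable step bears on this change, so its size and direction in this assay cannot be foreseen from the measured pair, and the expectation is that compound 3 again stays at the limit, with a step that the limit leaves unreadable from compound 2 to compound 3 estimated as no readable change. Compound 3 is therefore expected to give 150000 nM in this assay, with a range from 60000 nM to 400000 nM.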

Compound 3, half-maximal inhibitory concentration: > 100000 nM
Compound 3 ended at the assay's limit (the forecaster's own chance of this, stated with the estimate: 85%); the middle value does not contradict the limit.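

No new step can be read among compound 1, compound 2 and compound 3, because in this assay each result is a limit of the assay and not a number: the limit of > 100000 nM in this assay, at which 3 of the 3 values shown sit.

The compounds shown leave open how these amino groups on the shared core rank in this assay, and at what concentration, if any, they would harm the cells.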